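The source may report more compounds than this note shows. Statements on the series, on what has been measured and on what is new or still open speak of the compounds shown alone.

Compound 1 `CC(C)C(/C=C1\NC(=O)NC1=O)c1ccc(-c2ccc3cccc(F)c3c2)[nH]c1=O` gives 43 nM in an assay on membranes from Chem-1 cells for displacement of a labelled ligand from prostaglandin E2 receptor EP3 subtype (Homo sapiens), read by scintillation counting, with a stated time of 2 h (on this read-out lower numbers stand for stronger inhibition and higher numbers for weaker inhibition), and holds the highest of the three numbers at hand. Compound 3 `CCC(/C=C1\OC(=O)NC1=O)(CC)c1ccc(-c2ccc3cc(F)cc(F)c3c2)[nH]c1=O` gives 28 nM, a value within the scatter of compound 1, whereas compound 2 `CCc1cccc2ccc(-c3ccc(C(/C=C4\OC(=O)NC4=O)(CC)CC)c(=O)[nH]3)cc12` gives 17 nM, a gap that lies beyond it. Compound 4 `C/C(=C1/OC(=O)NC1=O)C(c1ccc(-c2ccc3cccc(F)c3c2)[nH]c1=O)C(C)C` has not yet been measured; it differs from compound 1 by a group of 9 heavy atoms (5 carbon, 1 nitrogen, 3 oxygen; one five-membered non-aromatic ring with 2 hetero atoms) in place of a group of 8 heavy atoms (4 carbon, 2 nitrogen, 2 oxygen; one five-membered non-aromatic ring with 2 hetero atoms), on a saturated chain carbon bound to an aromatic carbon and a saturated chain carbon. Going by the values given here, no pair of measured compounds differs in this one place alone, so the data hold no direct step for this change. The estimated step is a 1.4-fold lower number from compound 1 to compound 4 (0.16 log units; within the scatter), modest in size. Compound 4 is therefore estimated at 30 nM, with a range from 10 nM to 90 nM.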

Compound 4, inhibition constant: 17 nM
The estimate for compound 4 lay 1.8-fold (0.25 log units) above the measured number, within the range that was stated.
By their numbers in this assay, from the lowest: compounds 2, 4, 3 and 1 (each within the scatter of the next, the first and the last beyond it).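

In this assay, the group of 9 heavy atoms in place of the group of 8 heavy atoms, on a saturated chain carbon bound to an aromatic carbon and a saturated chain carbon, gives a 2.5-fold lower number from compound 1 to compound 4 (0.40 log units; beyond the scatter). Going by these compounds alone, this is the first direct reading at this place, and it shows that the number responds to this exchange with the rest of compound 1 unchanged. No measurement at hand accounts for the step. On these data alone, whether the same exchange gives a similar step on another core remains open, as does how a carboxylic acid or a nitrile at this carbon would read.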